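The compounds below may be only part of what the source reports. "The series", "measured", "known", "first", "only" and "open" are said of these compounds alone.

In a functional assay on NRK-49F cells (Rattus norvegicus) for cytotoxicity, read by MTT assay, with a stated time of 24 h (on this read-out lower numbers stand for stronger inhibition and higher numbers for weaker inhibition), compound 1 `COc1ccc(/C=C(\C#N)C(=O)N/N=C(\C)c2c(O)c3ccc(O)cc3oc2=O)cc1OC` gives 45300 nM and compound 2 `C/C(=N\NC(=O)/C(C#N)=C/c1ccc(Br)cc1)c1c(O)c2ccc(O)cc2oc1=O` gives 49600 nM, so compound 2 stands level with compound 1 within the scatter. Compound 3 `C/C(=N\NC(=O)/C(C#N)=C/c1ccc(N(C)C)cc1)c1c(O)c2ccc(O)cc2oc1=O` has dimethylamino in place of bromo on an aromatic carbon, para to a large group: dimethylamino in place of bromo on an aromatic carbon. Within the data shown here, the only measured step that bears on this change is a 1.1-fold higher number from compound 1 to compound 2 (0.04 log units; within the scatter), which lies within the scatter. It is a single step at a shared position, so no change beyond the scatter is expected in this assay. The expected step is a 1.1-fold lower number from compound 2 to compound 3 (0.02 log units; within the scatter). For compound 3 the estimate is 47000 nM, with an estimated range of 22000 nM to 90000 nM.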

Compound 3, half-maximal inhibitory concentration: 53400 nM
The estimate for compound 3 lay 1.1-fold (0.06 log units) below the measured number; the range from low to high includes it.
By their numbers in this assay, from the lowest: compounds 1, 2 and 3 (each within the scatter of the next).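

In this assay, dimethylamino in place of bromo gives a 1.1-fold higher number from compound 2 to compound 3 (0.03 log units; within the scatter) and 4-(dimethylamino)phenyl in place of 3,4-dimethoxyphenyl gives a 1.2-fold higher number from compound 1 to compound 3 (0.07 log units; within the scatter) and both steps lie within the scatter. A nitrogen-bearing group on this aromatic carbon therefore stands level with bromo, and the three compounds shown are not told apart by this read-out. Nothing measured here offers an explanation for this.

The compounds shown leave open whether a carboxylic acid or a longer chain on this aromatic carbon would give a step beyond the scatter.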